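Cycloalkyl exchange on the shared core: a larger hydroxycycloalkyl

This account rests on a few compounds, and the source may have more. Where it says the series, first, only, none or still open, it means among the compounds named here.

Compound 1 `N#Cc1cnc(NCc2cnccc2C(F)(F)F)cc1N[C@H]1C[C@H](O)C1` gives only a limit in an assay on isolated protein for inhibition of protein kinase C delta type (Homo sapiens), read by TR-FRET, with a stated time of 2 h (on this read-out higher numbers stand for weaker inhibition and lower numbers for stronger inhibition), namely > 10000 nM. Compound 2 `N#Cc1cnc(NCc2ccccc2)cc1N[C@H]1CC[C@@H](O)CC1` likewise sits at a limit in this assay, at > 10000 nM. Among the measured compounds shown here, compound 3 `N#Cc1cnc(NCc2cncnc2C(F)(F)F)cc1N[C@H]1CC[C@@H](O)CC1` is the one compound here with a number, giving 450 nM in this assay. Compound 1 thus stands at the limit of > 10000 nM in this assay, at which 2 of the 3 values shown sit, so its true value is not known, only bounded. Compound 4 `CC1(C)C[C@H](Nc2cc(NCc3cnccc3C(F)(F)F)ncc2C#N)CC[C@H]1O` carries the change (4-hydroxy-3,3-dimethylcyclohexyl in place of 3-hydroxycyclobutyl on a nitrogen on an aromatic ring). For the measured compounds named here, no measured pair in the set isolates this exchange, so the size of the step is open; the expectation is a move toward stronger inhibition in this assay, though compound 4 may still fall at the limit. Compound 4 is estimated at 3000 nM, between 500 nM and 20000 nM, corresponding to an expected step of an at least 3.3-fold lower number from compound 1 to compound 4 (0.52 log units; beyond the scatter).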

Compound 4, half-maximal inhibitory concentration: 2200 nM
Compound 4: the middle estimate sits 1.4-fold (0.13 log units) above what was measured; measured number inside the range.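

On the core of compound 1, the exchange to 4-hydroxy-3,3-dimethylcyclohexyl brings a measurable number in this assay, with an at least 4.5-fold lower number from compound 1 to compound 4 (0.65 log units; beyond the scatter). The position on a nitrogen on an aromatic ring therefore accepts the larger six-membered ring with its 3,3-dimethyl substitution, and inhibition is stronger with it. Compound 1 gives only a limit, so this step is a bound and not a size: the limit of > 10000 nM in this assay, at which 2 of the 4 values shown sit.

Still open, going by these compounds, is whether ring size or the 3,3-dimethyl substitution carries the step, which 4-hydroxycyclohexyl on the core of compound 1 would separate. Also open, on these data alone, is whether an amine in place of the hydroxyl would hold the number.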